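A few compounds are considered here, and "the series" means these few. Any claim that something is new, unique, unknown or untested is made for them only; others in the source may bear on it.

Working notes on the series. Compound 1 `COc1cccc(-c2cc(C(=O)Nc3ccc(Oc4ccnc5cc(OCCCN6CCCCC6)c(OC)cc45)c(F)c3)c3ccccc3n2)c1` has no single number in a functional assay on U-87MG ATCC cells (Homo sapiens) for cytotoxicity, read by MTT assay, with a stated time of 72 h; a lower number here means a stronger inhibitor, a higher number a weaker inhibitor: the entry reads "not determined" (no result reported). Going by the values given here, compound 2 `COc1cc2c(Oc3ccc(NC(=O)c4cc(-c5ccc(F)cc5)nc5ccccc45)cc3F)ccnc2cc1OCCCN1CCCCC1`, which shares the core, gives 980 nM in this assay, the only measured value in the set. Compound 3 `COc1cccc(-c2cc(C(=O)Nc3ccc(Oc4ccnc5cc(OCCCN6CCCCC6)c(OC)cc45)c(F)c3)c3cc(F)ccc3n2)c1` is compound 1 with one change, (fluoro in place of hydrogen on an aromatic carbon), fluoro in place of hydrogen on an aromatic carbon. Among the compounds with values here, with no measured step for compound 1 in this assay, no step beyond the usual scatter is expected from this change in either direction. Compound 3 is accordingly estimated at 1000 nM in this assay, in the range 300 nM to 4000 nM.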

Compound 3, half-maximal inhibitory concentration: 1610 nM
Estimate against measurement, compound 3: 1.6-fold (0.21 log units) below; low and high end bracket the measured number.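

In this assay no step can be read between compound 1 and compound 3. The compounds shown leave open what fluoro in place of hydrogen on this aromatic carbon does to the read-out. No other data bear on this result.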